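The source may report more compounds than this note shows. Statements on the series, on what has been measured and on what is new or still open speak of the compounds shown alone.

Working notes on the series. Within the data shown here, compound 1 `CC(C)/C(=N\O)c1ccc(Sc2cc(F)cc(C3CCOCC3)c2)cc1` holds the higher of the two numbers known in a functional assay (blood) for inhibition, with Homo sapiens as the target (on this read-out lower numbers stand for stronger inhibition and higher numbers for weaker inhibition), where compound 1 gives 300 nM. Compound 2 `COC1(c2csc(Sc3ccc4c(c3)OCC/C4=N\OCC#N)c2)CCOCC1` gives 60 nM, the lower number, and the gap between these two values lies beyond the scatter. Compound 3 `C/C(=N\OCC#N)c1ccc(Sc2cc(F)cc(C3CCOCC3)c2)cc1` is not yet measured; it differs from compound 1 in one place: a group of 7 heavy atoms (4 carbon, 2 nitrogen, 1 oxygen; no ring) in place of a group of 6 heavy atoms (4 carbon, 1 nitrogen, 1 oxygen; no ring), on an aromatic carbon. Among the measured compounds shown here, no measured pair isolates this change, so the direction rests on little. A moderate step toward a lower number is expected, a 2.0-fold lower number from compound 1 to compound 3 (0.30 log units; within the scatter). Compound 3 is estimated at 150 nM, within 60 nM to 400 nM.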

Compound 3, half-maximal inhibitory concentration: 20 nM
For compound 3 the middle estimate is 7.5-fold (0.88 log units) above the measured one, and the stated range ends above it.
By their numbers in this assay, from the lowest: compound 3; then compound 2; then compound 1.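

In this assay, the exchange on the aromatic carbon, para to a large group, gives a 15-fold lower number from compound 1 to compound 3 (1.18 log units; beyond the scatter), so this position responds strongly to this change. The leaving group has 1 hydrogen-bond donor; the entering group has 0 hydrogen-bond donors and a triple bond. No available evidence accounts for the size of this step. This single pair cannot show which part of the entering group carries the step. Also open, on these data alone, is how the series would respond to a primary amine or a carboxylic acid at the end of that group.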